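This account rests on a few compounds, and the source may have more. Where it says the series, first, only, none or still open, it means among the compounds named here.

Compound 3 `O=C(O)CCCCC[C@@H]1[C@@H](CNS(=O)(=O)c2ccc(F)cc2)CC[C@H]1F` carries a fully saturated acid chain on the shared core. In a functional assay on a cell-free system (plasma) for inhibition of thromboxane A2 receptor (Homo sapiens), read by turbidimetry (a higher number here means a weaker inhibitor, a lower number a stronger inhibitor), compound 3 gives 4700 nM, the higher of the two single numbers in this set. For the measured compounds named here, its nearest neighbour is compound 2 `O=C(O)COCCCC[C@@H]1[C@@H](CNS(=O)(=O)c2ccc(F)cc2)CC[C@H]1F`, for which this assay shows 650 nM; the step of a 7.2-fold higher number from compound 2 to compound 3 (0.86 log units; beyond the scatter) is the only one-point change measured here. Compound 1 `O=C(O)CC/C=C\C[C@@H]1[C@@H](CNS(=O)(=O)c2ccc(F)cc2)CC[C@H]1F`, whose chain holds a double bond, has no single number: repeated runs gave 1900 nM; 1900 nM; 650 nM (3 entries), and the several entries of compound 1 in this assay, 1900 nM; 1900 nM; 650 nM (3 entries) shows how far such repeats drift.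

Compound 4 `O=C(O)CCC/C=C\C[C@@H]1[C@@H](CNS(=O)(=O)c2ccc(F)cc2)CC[C@H]1F` is reached from compound 3 by the change (5-carboxypent-1-en-1-yl in place of 4-carboxybutyl on a saturated chain carbon bound to a saturated ring carbon). Going by the values given here, no measured step covers this change directly. The step from compound 2 to compound 3 shows that altering the chain while the acid end stays in place moves the number well beyond the scatter. Compound 4 combines the chain described in that change with the double bond of compound 1, and compound 1 gives 1900 nM; 1900 nM; 650 nM (3 entries) while compound 2 gives 650 nM, both well under compound 3. Compound 4 is therefore expected to improve on compound 3 by about a 5.2-fold lower number from compound 3 to compound 4 (0.72 log units; beyond the scatter). For compound 4 the estimate in this assay is 900 nM, with a range from 300 nM to 3000 nM.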

Compound 4, half-maximal inhibitory concentration: 2000 nM
Estimate against measurement, compound 4: 2.2-fold (0.35 log units) below, within the range that was stated.
By their numbers in this assay, from the lowest: compound 2; then compound 4; then compound 3.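

At this place, on a saturated chain carbon bound to a saturated ring carbon, 5-carboxypent-1-en-1-yl in place of 4-carboxybutyl gives a 2.4-fold lower number from compound 3 to compound 4 (0.37 log units; beyond the scatter) in this assay, so lengthening the chain while adding a double bond lowers the number from the saturated acid chain. The new chain does not match 3-(carboxymethoxy)propyl at the same place: a 3.1-fold higher number from compound 2 to compound 4 (0.49 log units; beyond the scatter) remains between the two, and the chain carrying the carboxymethoxy group keeps the lower number. Both steps lie beyond the usual scatter, but they are modest and should be read with the drift among repeats in mind: the several entries of compound 1 in this assay, 1900 nM; 1900 nM; 650 nM (3 entries).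

The step to compound 4 changes the chain in two ways at once, and the compounds shown do not separate the effect of the double bond from that of the added carbon; a saturated 5-carboxypentyl group at this place would divide the two. Also open, on these data alone, is whether a tetrazole at the end of the chain in place of the carboxylic acid would keep the number of any of these chains.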